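The compounds below may be only part of what the source reports. "The series", "measured", "known", "first", "only" and "open" are said of these compounds alone.

Compound 3 `C[Se]c1nc(NCc2ccccc2)c2ccccc2n1` stands at a limit rather than at a number: in a functional assay on MCF7 cells (Homo sapiens) for cytotoxicity, read by MTT assay, with a stated time of 72 h (a higher number here means that more compound is tolerated, a lower number that less compound is tolerated), compound 3 gives > 100000 nM, which is a limit of the assay. Compound 1 `COc1ccc(CNc2nc([Se]C)nc3ccccc23)cc1` carries a methoxy group where compound 3 carries hydrogen. In this assay compound 1 gives > 100000 nM, again a limit. The step from compound 1 to compound 3 is therefore unreadable: a step that the two limits leave unreadable from compound 1 to compound 3. Compound 2 `CCCCC[Se]c1nc(NCc2ccc(SC)cc2)c2ccccc2n1` carries a methylsulfanyl group on the same aromatic carbon and a pentylselanyl group in place of the methylselanyl group of compound 3; in this assay compound 2 gives 95300 nM. Compound 4 `CSc1ccc(CNc2nc([Se]C)nc3ccccc23)cc1` differs from compound 3 by methylsulfanyl in place of hydrogen on an aromatic carbon. For the measured compounds named here, with the limit of > 100000 nM in this assay, at which 2 of the 3 values shown sit, no measured step of readable size bears on this change. The step from compound 3 to compound 4 is expected to be a number no higher from compound 3 to compound 4 (the limit leaves the size open), nothing beyond the scatter. Compound 4 is therefore estimated at 100000 nM, within a range from 50000 nM to 250000 nM, and quite possibly reported only as a limit.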

Compound 4, concentration lethal to 50% of the cells: > 100000 nM
Compound 4 ended at the assay's limit; the forecaster's own chance of this, stated with the estimate: 60%; the middle value sits exactly at the limit.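

With the methylselanyl group kept, methylsulfanyl on this aromatic carbon joins hydrogen and methoxy at the limit in this assay, so none of these three groups gives a measured number there. With methylsulfanyl held in place, pentylselanyl and methylselanyl can now be compared, and the result is an at least 1.0-fold higher number from compound 2 to compound 4 (0.02 log units; that floor lies within the scatter) and shows no change that can be told from the scatter. The steps that join compound 4 to compound 1 and to compound 3 cannot be read, because both ends of each step sit at the same limit: the limit of > 100000 nM in this assay, at which 3 of the 4 values shown sit.

Going by these compounds, whether hydrogen, methoxy and methylsulfanyl differ at all on this carbon remains open. So does whether an amine or a carboxylic acid there, with the methylselanyl group kept, would give a measured number in this assay.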